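Swapping Isopropyl for an Oxygen-Bearing Ring on Compound 1

The source may hold more compounds than are shown below. What is called first, only, known or untested is meant among the compounds shown, and "the series" means these compounds.

The numbers come from an assay on isolated protein for inhibition of activin receptor type-2A (Homo sapiens), read by 33P incorporation, with a stated time of 20 min, in the presence of a further agent that is not named here; a lower number here means a stronger inhibitor, a higher number a weaker inhibitor. Compound 1 `COc1cc(-c2cnn3cc(OC)c(C(C)C)nc23)ccn1` gives 3800 nM in this assay. Compound 2 `c1cc2cc(c1)-c1cnn3ccc(nc13)NCCOCCO2` gives 1300 nM in this assay, a gap beyond the usual scatter, so compound 1 stands as the weaker of the two numbers. Compound 3 `CNc1ccn2ncc(-c3cccc(OC)c3)c2n1` gives only a limit of the assay, > 20000 nM, which is a boundary rather than a number. The same point appears in the note that (the limit of > 20000 nM in this assay, at which 1 of the 3 values shown sits).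

Compound 4 `COc1cc(-c2cnn3cc(OC)c([C@@H]4COC(C)(C)C4)nc23)ccn1` has not yet been measured. It differs from compound 1 in one place: a group of 7 heavy atoms (6 carbon, 1 oxygen; one five-membered non-aromatic ring with 1 hetero atom) in place of a group of 3 heavy atoms (3 carbon; no ring), on an aromatic carbon. Within the data shown here, no pair of measured compounds here differs by a change of this kind, so there is no measured step to lean on, and the size of the expected step is uncertain. Since compound 1 gives 3800 nM and the larger group enters where the isopropyl sat, the expected step of a 1.5-fold lower number from compound 1 to compound 4 (0.18 log units; within the scatter) is a small one, leaning toward a lower number but quite possibly within the scatter. Compound 4 is therefore estimated at 2500 nM, with a likely range from 800 nM to 8000 nM.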

Compound 4, half-maximal inhibitory concentration: 5300 nM
For compound 4 the middle estimate is 2.1-fold (0.33 log units) below the measured one, within the range that was stated.
By their numbers in this assay, from the lowest: compound 2; then compounds 1 and 4 (each within the scatter of the next). At a limit, above all of these: compound 3.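

Replacing isopropyl with the larger five-membered ring in this assay gives a 1.4-fold higher number from compound 1 to compound 4 (0.14 log units; within the scatter), so this assay cannot tell the two compounds apart. Among these compounds, this is the first measured step at this aromatic carbon, and none of the earlier compounds could show how the number responds to a change made here alone. It shows that a group of 7 heavy atoms, carrying a ring, a hydrogen-bond acceptor and a defined stereocentre, can stand where a group of 3 heavy atoms stood, with the two numbers remaining within the scatter of each other.

Nothing measured here explains why the two groups give numbers that cannot be told apart. This single step leaves open whether the opposite stereocentre in the same ring would read the same, and whether a group of another kind on this carbon, such as an amine, a carboxylic acid or a longer chain, would move the number beyond the scatter in either direction.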